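A Second Methoxy Group and the Inhibition Expected From It

The compounds below may be only part of what the source reports. "The series", "measured", "known", "first", "only" and "open" are said of these compounds alone.

Compound 1 `COc1cc(/C(Cl)=C/C=C(\C#N)C(=O)c2c[nH]c3ccccc23)cc(OC)c1OC` and compound 2 `COc1ccc(/C(Cl)=C/C=C(\C#N)C(=O)c2c[nH]c3ccccc23)cc1` share one core and differ only in the methoxy pattern on one aromatic ring. In a functional assay for inhibition, with a stated time of 30 min, tested at 1 mM (a higher number here means more inhibition at the concentration tested (going by the name of the read-out), a lower number less inhibition), compound 1 gives 21.1%, and compound 2 gives 23.4%. Compound 2 holds the higher of the two numbers, yet the gap lies within the scatter, so neither compound can be set above the other. Compound 3 `COc1ccc(/C(Cl)=C/C=C(\C#N)C(=O)c2c[nH]c3ccccc23)cc1OC` carries, relative to compound 2, a (methoxy in place of hydrogen on an aromatic carbon). Within the data shown here, no step between measured compounds is known; as compound 1, with its further methoxy groups, gives 21.1% close to compound 2, the step is expected to stay within the scatter, a number 1.4 percentage points lower from compound 2 to compound 3 (within the scatter). Compound 3 is therefore estimated at 22%, in the range 10% to 35%.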

Compound 3, a percentage reported as inhibition, at one concentration (the size of the read-out at that concentration, not a potency): 15.8%
Compound 3: the middle estimate sits 6.2 percentage points above what was measured; measured number inside the range.
By their numbers in this assay, from the lowest: compounds 3, 1 and 2 (each within the scatter of the next).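

Placing a methoxy group on this aromatic carbon, ortho to a methoxy group and meta to a large group, gives a number 7.6 percentage points lower from compound 2 to compound 3 (within the scatter) in this assay, so the change cannot be told apart from repeat variation. The other step, a number 5.3 percentage points lower from compound 1 to compound 3 (within the scatter), likewise shows no separation, so these three methoxy patterns remain indistinguishable in this read-out. No available evidence bears on these numbers. On these data alone, it remains open whether an amine or a carboxylic acid on this carbon would give a step beyond the scatter.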